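A few compounds are considered here, and "the series" means these few. Any claim that something is new, unique, unknown or untested is made for them only; others in the source may bear on it.

Measured so far in an ADME assay on the whole organism (Mus musculus, strain C57BL/6) for pharmacokinetics, read by LC-MS, at a dose of 10 mg/kg by the oral route; on this read-out lower numbers stand for lower exposure and higher numbers for higher exposure at the dose given:
- compound 1, `CCCCOc1ccc(Nc2nc3nonc3nc2O)cc1`: 3400 nM
- compound 2, `CC(C)(C)c1ccc(Nc2nc3nonc3nc2O)cc1`: 22300 nM

Compound 2 stands highest of the two numbers in this assay; its nearest neighbour is compound 1, with a 6.6-fold higher number from compound 1 to compound 2 (0.82 log units; beyond the scatter) separating the pair.

Compound 3, `CCCCc1ccc(Nc2nc3nonc3nc2O)cc1`, is not yet measured. It differs from compound 2 by butyl in place of tert-butyl on an aromatic carbon, the two sharing the same atoms joined differently. Going by the values given here, the only measured step, from compound 1 to compound 2, swaps butoxy for tert-butyl and is therefore a different change; no measured pair shows butyl against tert-butyl, so nothing here fixes the direction of the step to compound 3. Among the compounds with values here, the single step on record is modest, so a step of similar or smaller size is expected here, with no firm direction. Compound 3 is therefore expected to give 12000 nM in this assay, range 4000 nM to 35000 nM, meaning a 1.9-fold lower number from compound 2 to compound 3 (0.27 log units; within the scatter) as the expected step.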

Compound 3, maximal plasma concentration: 12000 nM
Estimate against measurement, compound 3: no gap at the digits printed; the range from low to high includes it.
By their numbers in this assay, from the lowest: compound 1; then compounds 3 and 2 (each within the scatter of the next).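

In this assay, moving the same four carbons from a tert-butyl to a butyl arrangement on the aromatic carbon gives a 1.9-fold lower number from compound 2 to compound 3 (0.27 log units; within the scatter), so this read-out does not separate the branched and straight chains at this position. The straight chains also allow a comparison without branching: butyl in place of butoxy gives a 3.5-fold higher number from compound 1 to compound 3 (0.55 log units; beyond the scatter). Compounds 2 and 3 thus both stand apart from compound 1, and the gap to butoxy does not depend on the tert-butyl group alone.

On these data alone, whether a propyl chain, a longer alkyl chain, an amine or a carboxylic acid at this position would stay with the two carbon chains or fall nearer to butoxy remains open. The compounds shown come with no other measurement that could account for either step.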